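Phenylethynyl in place of the biaryl substituent

This account rests on a few compounds, and the source may have more. Where it says the series, first, only, none or still open, it means among the compounds named here.

The series shares one core, shown in compound 1 `CC(C(=O)NCc1ccc(C(F)(F)F)nc1-c1ccccc1)c1ccc(NS(C)(=O)=O)c(F)c1`, which gives 6.4 nM in an assay on CHO cells for antagonist activity at transient receptor potential cation channel subfamily V member 1 (Homo sapiens), read by FLIPR; a higher number here means a weaker inhibitor, a lower number a stronger inhibitor. Compound 2 `COc1ccc(-c2nc(C(F)(F)F)ccc2CNC(=O)C(C)c2ccc(NS(C)(=O)=O)c(F)c2)cc1F` gives 4.2 nM and holds the lowest of the three numbers; its nearest neighbour is compound 1, a 1.5-fold lower number from compound 1 to compound 2 (0.18 log units; within the scatter), and its furthest is compound 3 `COc1ccc(-c2nc(C(F)(F)F)ccc2CNC(=O)C(C)c2ccc(NS(C)(=O)=O)c(F)c2)cc1OC`, which gives 25.6 nM, a 6.1-fold higher number from compound 2 to compound 3 (0.78 log units; beyond the scatter). The third measured step, a 4.0-fold higher number from compound 1 to compound 3 (0.60 log units; beyond the scatter), is of the same modest size.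

Compound 4 `CC(C(=O)NCc1ccc(C(F)(F)F)nc1C#Cc1ccccc1)c1ccc(NS(C)(=O)=O)c(F)c1` differs from compound 2 in one place: 2-phenylethynyl in place of 3-fluoro-4-methoxyphenyl on an aromatic carbon. Within the data shown here, no measured step alters the aromatic carbon in this way; the three steps only exchange substituents on the phenyl ring, and of these the exchange in a 1.5-fold lower number from compound 1 to compound 2 (0.18 log units; within the scatter) stayed within the scatter. Among the measured compounds shown here, the aryl of compound 4 is unsubstituted, as in compound 1, so the value of compound 1 is the closer anchor; the triple bond has no precedent here. The expected step is therefore a 2.4-fold higher number from compound 2 to compound 4 (0.38 log units; beyond the scatter), toward a somewhat higher number, with wide uncertainty. Compound 4 is estimated at 10 nM in this assay, within 3 nM to 40 nM.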

Compound 4, inhibition constant: 0.8 nM
Compound 4: the middle estimate sits 13-fold (1.10 log units) above what was measured, and the stated range ends above it.
By their numbers in this assay, from the lowest: compound 4; then compounds 2 and 1 (each within the scatter of the next); then compound 3.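

With 2-phenylethynyl on the aromatic carbon next to the ring nitrogen, the number in this assay falls below those of all three aryl compounds, with an 8.0-fold lower number from compound 1 to compound 4 (0.90 log units; beyond the scatter) and a 5.3-fold lower number from compound 2 to compound 4 (0.72 log units; beyond the scatter) and a 32-fold lower number from compound 3 to compound 4 (1.51 log units; beyond the scatter) in turn. The earlier steps shown here changed only substituents on the phenyl ring, whereas this change puts a triple bond between that ring and the core, and an unsubstituted phenyl is enough to give the lowest number of the set. Nothing available accounts for this gain.

On these data alone, whether substituents on the phenyl of 2-phenylethynyl would follow the order seen with the directly attached aryl groups remains open. Also open, as far as these compounds go, is whether the triple bond itself matters or only the longer link, which 2-phenylethyl or 2-phenylethenyl in the same place would separate.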